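The compounds below may be only part of what the source reports. "The series", "measured", "known", "first", "only" and "open" are said of these compounds alone.

Two compounds of the series carry a measurement in an assay on isolated protein for displacement of a labelled ligand from 5-hydroxytryptamine receptor 6 (Homo sapiens); on this read-out higher numbers stand for weaker inhibition and lower numbers for stronger inhibition. Compound 1, `NC[C@@H]1CCCc2cc(S(=O)(=O)c3c[nH]c4ccccc34)ccc21`, gives 0.0501 nM in this assay. Compound 2, `O=C1CN(C[C@@H]2CCCc3cc(S(=O)(=O)c4cccc(F)c4)ccc32)CCN1`, gives 6.31 nM in this assay, and this is the higher of the two numbers; the gap to compound 1 lies well beyond the scatter of repeated measurements, so compound 2 is the weaker binder of the pair. Among the compounds with values here, the two compounds differ in more than one place, so no single structural step between them can be read from the data.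

Compound 3, `CN(C[C@@H]1CCCc2cc(S(=O)(=O)c3cccc(F)c3)ccc21)S(C)(=O)=O`, has not yet been measured in this assay. It differs from compound 2 in one place: methyl(methylsulfonyl)amino in place of 3-oxopiperazin-1-yl on a saturated chain carbon bound to a saturated ring carbon. Within the data shown here, no measured pair shows the effect of this exchange, so the direction must be taken as an open expectation. A step of moderate size toward weaker binding, beyond the scatter, is expected for this change, giving a 7.9-fold higher number from compound 2 to compound 3 (0.90 log units; beyond the scatter).

For compound 3 the estimate in this assay is 50 nM, with a range from 8 nM to 300 nM.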

Compound 3, inhibition constant: 0.398 nM
Compound 3: middle estimate off by 130-fold (2.10 log units), on the high side; measured number outside the range, below it.
By their numbers in this assay, from the lowest: compound 1; then compound 3; then compound 2.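

In this assay, within the data shown here, methyl(methylsulfonyl)amino in place of 3-oxopiperazin-1-yl on a saturated chain carbon bound to a saturated ring carbon gives a 16-fold lower number from compound 2 to compound 3 (1.20 log units; beyond the scatter), the first single-place reading at this position and a large one. It shows that this position responds strongly to the group it carries, and that strong binding here requires neither the six-membered non-aromatic ring nor the hydrogen-bond donor of 3-oxopiperazin-1-yl, as the entering group has no ring and 0 hydrogen-bond donors. No measurement is available that accounts for the size or direction of this step.

The ring, the amide hydrogen and the sulfonyl group all change together in this one exchange, so the compounds shown do not separate their contributions, and the step is read on the core of compound 2 alone. Open questions are how an acetyl group in place of the methylsulfonyl on the same nitrogen would read, and how piperidin-1-yl would read in place of 3-oxopiperazin-1-yl.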